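Working notes: 4-methylbenzyl to benzyl on compound 1

The compounds below may be only part of what the source reports. "The series", "measured", "known", "first", "only" and "open" are said of these compounds alone.

- compound 1 `COc1ccc(C(O)(Cc2ccc(C)cc2)c2cccc3ccccc23)c(OC)c1OC` gives > 20000 nM (a limit)
- compound 2 `COc1ccc(C(c2ccc(O)cc2)c2cccc3ccccc23)c(OC)c1OC` gives 16000 nM

Both entries come from a functional assay on HCT-116 cells (Homo sapiens) for inhibition, read by sulforhodamine B assay, with a stated time of 48 h; on this read-out lower numbers stand for stronger inhibition and higher numbers for weaker inhibition. Compound 1 stands at the limit of > 20000 nM in this assay, at which 1 of the 2 values shown sits, and carries no number. Compound 3 `COc1ccc(C(O)(Cc2ccccc2)c2cccc3ccccc23)c(OC)c1OC` has hydrogen in place of methyl on an aromatic carbon, para to a large group (hydrogen in place of methyl on an aromatic carbon), and otherwise keeps the core of compound 1. For the measured compounds named here, no measured step covers this change. In this assay no step beyond the scatter is expected in either direction, and compound 2 at 16000 nM shows no strong inhibition either. The expected change is a number no higher from compound 1 to compound 3 (the limit leaves the size open) and stays within the scatter. For compound 3 the estimated value is 20000 nM with an expected range of 8000 nM to 40000 nM and a report as a limit remains likely.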

Compound 3, half-maximal inhibitory concentration: > 20000 nM
Compound 3 gave a limit, no number (the forecaster's own chance of this, stated with the estimate: 65%); the middle value sits exactly at the limit.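

No step can be read from compound 1 to compound 3, since both stand at the same limit: the limit of > 20000 nM in this assay, at which 2 of the 3 values shown sit.

Going by these compounds, whether hydrogen in place of methyl changes inhibition at all remains open.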